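Swapping methoxy for trifluoromethyl on compound 1

A few compounds are considered here, and "the series" means these few. Any claim that something is new, unique, unknown or untested is made for them only; others in the source may bear on it.

In an ADME assay on Vero cells (Chlorocebus sabaeus) for cytotoxicity, read by resazurin assay, with a stated time of 72 h (a lower number here means a stronger inhibitor, a higher number a weaker inhibitor), compound 1 (`COc1ccc(C(=O)CCN2CCN(c3ccc(Cl)cc3)CC2)cc1`) gives 300000 nM. Compound 2 (`COc1ccc(C(=O)CCN2CCN(c3ccc(Cl)cc3)CC2)cc1OC`) gives 185000 nM, and compound 3 (`O=C(CCN1CCN(c2ccc(Cl)cc2)CC1)c1ccc(F)c(Br)c1`) gives 206000 nM. All three numbers sit within the scatter of compound 1, so compound 1 stands level with the other two.

Compound 4 (`O=C(CCN1CCN(c2ccc(Cl)cc2)CC1)c1ccc(C(F)(F)F)cc1`) has not yet been measured. It carries trifluoromethyl in place of methoxy on an aromatic carbon.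

Going by the values given here, two measured steps bear on this change. The closer one also removes the methoxy, putting 3-bromo-4-fluorophenyl in place of 4-methoxyphenyl, and gives a 1.5-fold lower number from compound 1 to compound 3 (0.16 log units; within the scatter). Adding a second methoxy gives a 1.6-fold lower number from compound 1 to compound 2 (0.21 log units; within the scatter). Among the compounds with values here, neither step leaves the scatter, although no measured compound carries trifluoromethyl, so the comparison is indirect.

A step beyond the scatter is therefore not expected, and the estimated change is a 1.4-fold lower number from compound 1 to compound 4 (0.13 log units; within the scatter). For compound 4 the expected value is 220000 nM, with an estimated range from 110000 nM to 400000 nM.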

Compound 4, half-maximal inhibitory concentration: 54200 nM
Compound 4: the middle estimate sits 4.1-fold (0.61 log units) above what was measured; the measured number lies below the stated range.
By their numbers in this assay, from the lowest: compound 4; then compounds 2, 3 and 1 (each within the scatter of the next).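

At this place on the ring, para to a large group, the swap in this assay gives a 5.5-fold lower number from compound 1 to compound 4 (0.74 log units; beyond the scatter) and is the only step shown that leaves the scatter. The position therefore does respond to what sits on it, which compounds 2 and 3 could not show. Losing the methoxy is not enough on its own to produce such a step, since the change with a 1.5-fold lower number from compound 1 to compound 3 (0.16 log units; within the scatter) also removes it and stays within the scatter, and no measurement shown accounts for the difference between these two changes.

Still open, as far as these compounds go, is whether this step belongs to trifluoromethyl in particular or would also appear with a nitrile or a carboxylic acid at this place. Going by these compounds alone, also open is whether the same swap would give a step of this size with a longer chain in place of the one in compound 1.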